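Swapping a sulfonamide for an acetamide at the urea end

The compounds below may be only part of what the source reports. "The series", "measured", "known", "first", "only" and "open" are said of these compounds alone.

Measured so far in a functional assay on MDA-MB-231 cells (Homo sapiens) for antiproliferative activity, read by MTT assay, with a stated time of 72 h; a higher number here means a weaker inhibitor, a lower number a stronger inhibitor:
- Compound 1 `COc1ccc(NC(=O)Nc2cccc(-c3nc(-c4ccc(NC(=O)c5cccnc5)cc4Cl)no3)c2)cc1C(F)(F)F` gives 1700 nM.
- Compound 2 `C#Cc1ccc(NC(=O)Nc2cccc(-c3nc(-c4ccc(NC(=O)c5cccnc5)cc4Cl)no3)c2)cc1` gives only a limit, > 10000 nM, so no number is known for it.
- Compound 3 `O=C(Nc1ccc(NS(=O)(=O)C2CC2)cc1)Nc1cccc(-c2nc(-c3ccc(NC(=O)c4cccnc4)cc3Cl)no2)c1` gives 300 nM.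

Compound 3 has the lowest of the two real numbers here; compound 1 sits clearly higher, and compound 2 reaches no number at all. Compound 4 `CC(=O)Nc1ccc(NC(=O)Nc2cccc(-c3nc(-c4ccc(NC(=O)c5cccnc5)cc4Cl)no3)c2)cc1` differs from compound 3 in one place: acetyl in place of cyclopropylsulfonyl on a nitrogen on an aromatic ring. The same end of the molecule is where the two measured steps happen. Going from compound 1 to compound 2 gave an at least 5.8-fold higher number from compound 1 to compound 2 (0.76 log units; beyond the scatter), and going from compound 2 to compound 3 gave an at least 33-fold lower number from compound 2 to compound 3 (1.52 log units; beyond the scatter). Both steps pass through (the limit of > 10000 nM in this assay, at which 1 of the 3 values shown sits), so their true sizes are only bounded, not known, and neither of them removes a substituted nitrogen in the way the present change does. The evidence shows that this end of the molecule matters a great deal, but gives no direct read on trading cyclopropylsulfonyl for acetyl. Compound 4 is therefore expected to land near 800 nM, somewhere between 200 nM and 4000 nM. That amounts to an expected step of a 2.7-fold higher number from compound 3 to compound 4 (0.43 log units; beyond the scatter), with wide uncertainty in both directions.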

Compound 4, half-maximal inhibitory concentration: > 10000 nM
Compound 4: only a limit was reported (the forecaster's own chance of this, stated with the estimate: 10%); middle value at least 12-fold (1.09 log units) away from the limit.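

In this assay, compound 4 gives > 10000 nM, which is a limit and not a number. Even so, keeping the nitrogen on the aromatic ring and trading only cyclopropylsulfonyl for acetyl gives an at least 33-fold higher number from compound 3 to compound 4 (1.52 log units; beyond the scatter), so a nitrogen at this place is not enough on its own: among these compounds, the group it carries decides the outcome, which the earlier compounds could not show, since none of them kept that nitrogen while changing its group. The 4-acetamidophenyl end also falls short of the 4-methoxy-3-(trifluoromethyl)phenyl end, with an at least 5.8-fold higher number from compound 1 to compound 4 (0.76 log units; beyond the scatter), while the step between compound 2 and compound 4 cannot be read, since both stop at the same limit: the limit of > 10000 nM in this assay, at which 2 of the 4 values shown sit.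

On these data alone, with only these two groups compared on that nitrogen, it stays open whether the sulfonyl part or the cyclopropyl part accounts for the difference, and a methylsulfonyl group or a cyclopropanecarbonyl group on the same nitrogen would separate the two. As far as these compounds go, how a free amine at this place would read in this assay also stays open, as does the true value of compound 4.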